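This account rests on a few compounds, and the source may have more. Where it says the series, first, only, none or still open, it means among the compounds named here.

Measured compounds:
- compound 1, `C[C@@H](Nc1c(C(=O)NCc2ccc(F)cc2)nc(Br)c2cccnc12)c1ccccc1`: > 20000 nM
- compound 2, `N[C@H]1CC[C@H](Nc2c(C(=O)NCc3ccc(Cl)cc3Cl)nc(Br)c3cccnc23)CC1`: 5800 nM
- compound 3, `O=CNCCCCCCNc1nc(C(=O)NCc2ccc(F)cc2)c(O)c2ncccc12`: 16000 nM

All three were tested in a functional assay on MDA-MB-435 cells (Homo sapiens) for cytotoxicity, read by MTT assay, with a stated time of 72 h; on this read-out higher numbers stand for weaker inhibition and lower numbers for stronger inhibition. Compound 1 gives only a limit of the assay, > 20000 nM, so no number is known for it; it stands at the limit of > 20000 nM in this assay, at which 1 of the 3 values shown sits. Compound 2 gives 5800 nM, and compound 3 gives 16000 nM; both are weak on this scale, and no single-point step between any two of these compounds is available, so the values are taken as they stand.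

Compound 4, `Nc1cccc(Nc2c(C(=O)NCc3ccc(F)cc3)nc(Br)c3cccnc23)c1`, differs from compound 1 in one place: 3-aminophenyl in place of 1-phenylethyl on a nitrogen on an aromatic ring. For the measured compounds named here, nothing among the measured compounds shows how this change acts, since compound 1 itself gives only a limit. The expectation therefore rests on the fact that every measured compound is weak, and the step from compound 1 to compound 4 is expected to be an at least 1.3-fold lower number from compound 1 to compound 4 (0.12 log units; that floor lies within the scatter), not clearly beyond the scatter. Compound 4 is expected to give 15000 nM, in the range 4000 nM to 50000 nM.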

Compound 4, half-maximal inhibitory concentration: 8000 nM
Estimate against measurement, compound 4: 1.9-fold (0.27 log units) above, within the range that was stated.
By their numbers in this assay, from the lowest: compounds 2, 4 and 3 (each within the scatter of the next, the first and the last beyond it). At a limit, above all of these: compound 1.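

In this assay, placing 3-aminophenyl in place of 1-phenylethyl on a nitrogen on an aromatic ring gives an at least 2.5-fold lower number from compound 1 to compound 4 (0.39 log units; beyond the scatter), the first sign that this position can affect the read-out. Even after the change, compound 4 remains weak at 8000 nM, so this swap alone yields no strong inhibition of these cells. This step is only a floor, because compound 1 stands at a limit: the limit of > 20000 nM in this assay, at which 1 of the 4 values shown sits.

The change removes a defined stereocentre and the carbon next to it in the name 1-phenylethyl, and it adds an amine, so the compounds shown cannot say which of these differences matters. A plain phenyl on the same nitrogen would help separate them, and a carboxylic acid on that ring would show whether the amine can be replaced.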